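Acyl variation at the hydroxyl: plasma half-life notes

This account rests on a few compounds, and the source may have more. Where it says the series, first, only, none or still open, it means among the compounds named here.

Compound 1 `CC(=O)Oc1ccccc1C(=O)O[C@H]1CO[C@H]2[C@@H]1OC[C@H]2O` carries a free hydroxyl on its core. In an ADME assay on a cell-free system (plasma, Homo sapiens) for metabolic stability, with Plasma (Rattus norvegicus) as the target, read by HPLC, at pH 7.4 (on this read-out higher numbers stand for a longer-lived compound and lower numbers for a shorter-lived compound), compound 1 gives 0.055 h, the second highest of the three numbers, with compound 2 `CC(=O)Oc1ccccc1C(=O)O[C@H]1CO[C@H]2[C@@H]1OC[C@H]2OC(C)=O` nearest at 0.0608 h and compound 3 `CC(=O)Oc1ccccc1C(=O)O[C@H]1CO[C@H]2[C@@H]1OC[C@H]2OC(=O)c1ccccc1C` furthest at 0.035 h. Compound 4 `CC(=O)Oc1ccccc1C(=O)O[C@H]1CO[C@H]2[C@@H]1OC[C@H]2OC(=O)CO[N+](=O)[O-]` differs from compound 1 in one place: ((nitrooxy)methyl)carbonyl in place of hydrogen on an oxygen on a saturated carbon. The two measured acylations of the same hydroxyl bear on this step: a 1.1-fold higher number from compound 1 to compound 2 (0.04 log units; within the scatter) and a 1.6-fold lower number from compound 1 to compound 3 (0.20 log units; within the scatter); between the two esters, a 1.7-fold lower number from compound 2 to compound 3 (0.24 log units; within the scatter). Neither acylation produced a step beyond the scatter. For compound 4 no step beyond the scatter is therefore expected in this assay, the expected step being a 1.1-fold lower number from compound 1 to compound 4 (0.04 log units; within the scatter). Compound 4 is estimated at 0.05 h, within a range of 0.025 h to 0.1 h.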

Compound 4, half-life: 0.06 h
The estimate for compound 4 lay 1.2-fold (0.08 log units) below the measured number; measured number inside the range.
By their numbers in this assay, from the lowest: compounds 3, 1, 4 and 2 (each within the scatter of the next).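

In this assay the ((nitrooxy)methyl)carbonyl ester on the oxygen is a third acylation without a step beyond the scatter (a 1.1-fold higher number from compound 1 to compound 4 (0.04 log units; within the scatter)). It also stays within the scatter of both other esters (a 1.7-fold higher number from compound 3 to compound 4 (0.23 log units; within the scatter); a 1.0-fold lower number from compound 2 to compound 4 (0.01 log units; within the scatter)), so this read-out separates none of the four compounds at this oxygen. Nothing at hand explains this flat result.

From the compounds shown here alone, whether an acyl group carrying an amine or a carboxylic acid would give a step beyond the scatter remains open. The same holds for a longer chain.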